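Removing the carbamoyl-capped chain: what stability to expect

This account rests on a few compounds, and the source may have more. Where it says the series, first, only, none or still open, it means among the compounds named here.

Measured so far, in an ADME assay on microsomes from liver (Mus musculus) for metabolic stability, using NADPH, with a stated time of 10 min; on this read-out lower numbers stand for a less stable compound and higher numbers for a more stable compound
- compound 1 `NC/C=C\CN(C[C@H]1Cc2ncccc2CN1)[C@H]1CCCc2cccnc21` with 37%
- compound 2 `NC(=O)NC/C=C\CN(C[C@H]1Cc2ncccc2CN1)[C@H]1CCCc2cccnc21` with 10%

Compound 2 has the lower number of the two, at 10%, and the gap up to compound 1 lies beyond the usual scatter. The next compound is compound 3 `CN(C)CCCCN(C[C@H]1Cc2ncccc2CN1)[C@H]1CCCc2cccnc21`, and the change is a group of 6 heavy atoms (5 carbon, 1 nitrogen; no ring) in place of a group of 7 heavy atoms (4 carbon, 2 nitrogen, 1 oxygen; no ring), on a saturated chain carbon bound to an amine nitrogen. The group that enters is 3-(dimethylamino)propyl, which has no ring and no net charge.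

Among the measured compounds shown here, only one measured step bears on this change: a number 27 percentage points lower from compound 1 to compound 2 (beyond the scatter), with carbamoyl in place of hydrogen on an amine nitrogen. For the measured compounds named here, compound 3 carries no carbamoyl, so compound 1, at 37%, is the nearest guide, although its chain differs from the one in compound 3. A single step on a different chain is thin evidence, so a partial recovery is expected rather than a full return, and with wide uncertainty. The expected change is a number 15 percentage points higher from compound 2 to compound 3 (beyond the scatter). Compound 3 is estimated at 25%, with an expected range from 8% to 50%.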

Compound 3, percent of the compound remaining: 55%
For compound 3 the middle estimate is 30 percentage points below the measured one; measured number outside the range, above it.
By their numbers in this assay, from the lowest: compound 2; then compound 1; then compound 3.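

In this assay, replacing the carbamoyl-capped chain with 3-(dimethylamino)propyl gives a number 45 percentage points higher from compound 2 to compound 3 (beyond the scatter), a large step that takes stability past the level of the uncapped chain as well. The comparison with that uncapped chain matters most: 3-(dimethylamino)propyl in place of 3-aminoprop-1-en-1-yl gives a number 18 percentage points higher from compound 1 to compound 3 (beyond the scatter), so at this position the outcome depends on more than whether a carbamoyl is present, and the rest of the chain counts too. Nothing available here explains why this chain fares better.

Compound 1 and compound 3 differ in both the double bond of the chain and the methyl groups on its terminal nitrogen, so these compounds cannot show which of the two features goes with the higher number. A saturated chain ending in a plain amine, such as 4-aminobutyl, would help to separate those two features, while a longer chain or a carboxylic acid at the chain end would test how far this position tolerates other changes.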